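This account rests on a few compounds, and the source may have more. Where it says the series, first, only, none or still open, it means among the compounds named here.

Measured compounds:
compound 1 `C=CC(=O)N1C(=O)CC(c2ccc(C)cc2)Sc2ccccc21` — 87600 nM
compound 2 `C=CC(=O)N1C(=O)CC(c2cccc(Cl)c2)Sc2ccccc21` — 77500 nM
compound 3 `C=CC(=O)N1C(=O)CC(c2ccc(C(=O)OC)cc2)Sc2ccccc21` — 79600 nM

All three were tested in a functional assay on MOLT-4 cells (Homo sapiens) for cytotoxicity, read by CCK-8 assay, with a stated time of 24 h; on this read-out higher numbers stand for weaker inhibition and lower numbers for stronger inhibition. Compound 2 has the lowest of the three numbers, yet its gaps to compound 3 and to compound 1 both lie within the scatter, so the three cannot be told apart on these numbers. The two steps between measured compounds, a 1.1-fold lower number from compound 1 to compound 2 (0.05 log units; within the scatter) and a 1.1-fold lower number from compound 1 to compound 3 (0.04 log units; within the scatter), are likewise within the scatter: swapping the group on the saturated ring carbon or the group on the aromatic carbon left the read-out essentially unchanged.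

Compound 4 `C=CC(=O)N1C(=O)CC(c2ccccc2Cl)Sc2ccccc21` is not yet measured. It differs from compound 2 in one place: 2-chlorophenyl in place of 3-chlorophenyl on a saturated ring carbon. The same atoms are present, joined differently, with 3-chlorophenyl leaving and 2-chlorophenyl entering. Within the data shown here, no measured step covers a 2-chlorophenyl, so the only guide is that the one measured change at this saturated ring carbon stayed within the scatter. Compound 4 is therefore expected to show no step beyond the scatter, a 1.0-fold higher number from compound 2 to compound 4 (0.00 log units; within the scatter), and its estimated value is 78000 nM, with a range from 40000 nM to 160000 nM.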

Compound 4, half-maximal inhibitory concentration: 80300 nM
Compound 4: middle estimate off by 1.0-fold (0.01 log units), on the low side; the measured number falls inside the stated range.
By their numbers in this assay, from the lowest: compounds 2, 3, 4 and 1 (each within the scatter of the next).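

In this assay, among these compounds, a 1.0-fold higher number from compound 2 to compound 4 (0.02 log units; within the scatter) is the first measured case where the atoms stay the same and only the chlorine's place on the phenyl ring differs, and compound 2 and compound 4 cannot be told apart. The other comparison, a 1.1-fold lower number from compound 1 to compound 4 (0.04 log units; within the scatter), shows that 2-chlorophenyl also cannot be told apart from 4-methylphenyl on this saturated ring carbon, so this position has so far shown no response to these phenyl groups. Nothing measured here offers an explanation for this flat result.

Every group shown on this carbon is a substituted phenyl, so it remains open whether a carboxylic acid or an amine on that ring, or a longer chain in its place, would shift the read-out. On these data alone, the vinylcarbonyl group is the same in all four compounds, so what would happen with a saturated propanoyl group in its place also remains open.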